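The source may report more compounds than this note shows. Statements on the series, on what has been measured and on what is new or still open speak of the compounds shown alone.

Three compounds share one core and differ only in the aryl group on the amine nitrogen. Compound 1 `Fc1cccc(NCn2nc(-c3ccc4c(c3)OCCO4)oc2=S)c1` gives 6620 nM in a functional assay, with a stated time of 6 min (on this read-out higher numbers stand for weaker inhibition and lower numbers for stronger inhibition), the highest of the three numbers, though neither neighbour lies beyond the scatter: compound 2 `Fc1cccc(F)c1NCn1nc(-c2ccc3c(c2)OCCO3)oc1=S` gives 3320 nM and compound 3 `Cc1ccccc1NCn1nc(-c2ccc3c(c2)OCCO3)oc1=S` gives 3450 nM. The steps of a 2.0-fold lower number from compound 1 to compound 2 (0.30 log units; within the scatter) and a 1.9-fold lower number from compound 1 to compound 3 (0.28 log units; within the scatter) are the ones that bear on the next change, and both were small.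

Compound 4 `COc1ccccc1NCn1nc(-c2ccc3c(c2)OCCO3)oc1=S` carries the change (2-methoxyphenyl in place of 3-fluorophenyl on an amine nitrogen). With two aryl swaps on this nitrogen each giving only a 2.0-fold lower number from compound 1 to compound 2 (0.30 log units; within the scatter) or a 1.9-fold lower number from compound 1 to compound 3 (0.28 log units; within the scatter), the expected step of a 1.6-fold lower number from compound 1 to compound 4 (0.20 log units; within the scatter) is likewise small and downward at most. Compound 4 is therefore estimated at 4200 nM, within 1500 nM to 11000 nM.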

Compound 4, half-maximal inhibitory concentration: 6300 nM
For compound 4 the middle estimate is 1.5-fold (0.18 log units) below the measured one, and the stated range covers the measured number.
By their numbers in this assay, from the lowest: compounds 2, 3, 4 and 1 (each within the scatter of the next).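

In this assay the 2-methoxyphenyl group on this amine nitrogen gives steps that all lie within the scatter (a 1.1-fold lower number from compound 1 to compound 4 (0.02 log units; within the scatter)) and (a 1.8-fold higher number from compound 3 to compound 4 (0.26 log units; within the scatter)) and (a 1.9-fold higher number from compound 2 to compound 4 (0.28 log units; within the scatter)). The entering group counts one hydrogen-bond acceptor against none for 3-fluorophenyl, and that difference comes with no step beyond the scatter at this position. No measurement at hand accounts for these numbers. Going by these compounds, whether a carboxylic acid or a saturated amine in place of the aryl group on this nitrogen would give a step beyond the scatter stays open.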